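The source may report more compounds than this note shows. Statements on the series, on what has been measured and on what is new or still open speak of the compounds shown alone.

Measured compounds:
Compound 1 `N=C(N)c1ccc2[nH]c(-c3cc(F)cc(Cl)c3)cc2c1` gives 278000 nM in an assay on isolated protein for inhibition of acid-sensing ion channel 3 (Homo sapiens), read by patch clamp; on this read-out higher numbers stand for weaker inhibition and lower numbers for stronger inhibition.
Compound 2 `N=C(N)c1ccc2[nH]c(-c3cc(Cl)cc(Cl)c3)cc2c1` gives 133000 nM in this assay.

Within the data shown here, compound 2 holds the lower of the two numbers in this assay; the only measured step, a 2.1-fold lower number from compound 1 to compound 2 (0.32 log units; beyond the scatter), is modest but beyond the scatter. Compound 3 `N=C(N)c1ccc2[nH]c(-c3cc(Cl)cc(Cl)c3Cl)cc2c1` differs from compound 2 by chloro in place of hydrogen on an aromatic carbon. The measured step concerned chloro replacing fluoro, not chloro replacing hydrogen, so it bears on this change only loosely; it shows that more chlorine on this ring gave a modestly lower number. A small downward step or none beyond the scatter is therefore expected, a 1.5-fold lower number from compound 2 to compound 3 (0.17 log units; within the scatter). Compound 3 is estimated at 90000 nM, range 30000 nM to 270000 nM.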

Compound 3, half-maximal inhibitory concentration: 135000 nM
For compound 3 the middle estimate is 1.5-fold (0.18 log units) below the measured one, within the range that was stated.
By their numbers in this assay, from the lowest: compounds 2 and 3 (each within the scatter of the next); then compound 1.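

Chloro in place of hydrogen on this aromatic carbon, ortho to a chloro group and para to a chloro group, gives a 1.0-fold higher number from compound 2 to compound 3 (0.01 log units; within the scatter), so the number does not respond to this change. The lower number seen with chloro in place of fluoro in the earlier step therefore does not carry over to this added chloro. No available evidence explains this flat result. As far as these compounds go, it remains open whether a methoxy group, an amine or a carboxylic acid at this position would shift the number in either direction.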